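From a silicon-bearing group to formyl

This account rests on a few compounds, and the source may have more. Where it says the series, first, only, none or still open, it means among the compounds named here.

In a functional assay on KB cells (Homo sapiens) for cytotoxicity, read by sulforhodamine B assay (on this read-out lower numbers stand for stronger inhibition and higher numbers for weaker inhibition), compound 1 `C=C1[C@@H](OC(C)=O)C[C@@H]2[C@](C)(CO[Si](C)(C)C(C)(C)C)[C@H](OC(C)=O)CC[C@@]2(C)[C@@H]1C[C@@H](Nc1ccc(F)cc1)C1=CCOC1=O` gives 5090 nM and compound 2 `C=C1[C@@H](OC(C)=O)C[C@@H]2[C@](C)(CO[Si](C)(C)C(C)(C)C)[C@H](OC(C)=O)CC[C@@]2(C)[C@@H]1C[C@@H](Nc1ccccc1F)C1=CCOC1=O` gives 4740 nM, two numbers that lie within the scatter of each other. Compound 3 `C=C1[C@@H](OC(C)=O)C[C@@H]2[C@](C)(COC=O)[C@H](OC(C)=O)CC[C@@]2(C)[C@@H]1C[C@@H](Nc1ccc(F)cc1)C1=CCOC1=O` departs from compound 1 at one place, on an oxygen on a saturated carbon: a group of 2 heavy atoms (1 carbon, 1 oxygen; no ring) in place of a group of 7 heavy atoms (6 carbon, 1 silicon; no ring), on an oxygen on a saturated carbon. For the measured compounds named here, the only measured step, a 1.1-fold lower number from compound 1 to compound 2 (0.03 log units; within the scatter), places 2-fluorophenyl where 4-fluorophenyl stood on an amine nitrogen. That is a different place in the molecule, so it offers no direct guide to this change. Going by the values given here, nothing measured so far shows how this assay responds to a change at this oxygen, which leaves the direction open. As a cautious guess, a modest move towards a higher number is expected, and the expected change is a 1.4-fold higher number from compound 1 to compound 3 (0.14 log units; within the scatter). For compound 3 the estimated value is 7000 nM, with an expected range from 2500 nM to 20000 nM.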

Compound 3, half-maximal inhibitory concentration: 22900 nM
Estimate against measurement, compound 3: 3.3-fold (0.51 log units) below; measured number above the stated range.
By their numbers in this assay, from the lowest: compounds 2 and 1 (each within the scatter of the next); then compound 3.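

For the compounds shown here, this result is the first sign that this assay responds to a change on the oxygen on a saturated carbon: formyl in place of the silicon-bearing group brings a 4.5-fold higher number from compound 1 to compound 3 (0.65 log units; beyond the scatter) and moves the number beyond the usual scatter. Going by these compounds alone, the only earlier step, on the amine nitrogen, stayed within the scatter, so of the two places changed so far, only this oxygen has shifted the number measurably. No supporting data explain the rise, so the loss of silicon, the smaller group and the new formyl group cannot be told apart as its source.

The compounds shown leave open what a plain hydroxyl, an acetyl group or a trimethylsilyl group on this oxygen would give. They also leave open whether formyl has a similar effect when 2-fluorophenyl stands on the amine nitrogen, as in compound 2.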